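Working notes: methoxy to nitro in the series

A few compounds are considered here, and "the series" means these few. Any claim that something is new, unique, unknown or untested is made for them only; others in the source may bear on it.

Measured in a functional assay on HeLa cells (Homo sapiens) for antiproliferative activity, read by MTT assay, with a stated time of 48 h; a higher number here means a weaker inhibitor, a lower number a stronger inhibitor
- compound 1 `Cc1cc2nc(NC(c3cn(-c4ccccc4)nc3-c3ccc([N+](=O)[O-])cc3)c3c(O)ccc4ccccc34)sc2cc1C` gives 14700 nM
- compound 2 `Cc1cccc(-c2nn(-c3ccccc3)cc2C(Nc2nc3ccccc3s2)c2c(O)ccc3ccccc23)c1` gives 7020 nM
- compound 3 `COc1ccc(-c2nn(-c3ccccc3)cc2C(Nc2nc3ccccc3s2)c2c(O)ccc3ccccc23)cc1` gives 9340 nM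

Compound 3 lies within the scatter of both other compounds. Compound 4 `O=[N+]([O-])c1ccc(-c2nn(-c3ccccc3)cc2C(Nc2nc3ccccc3s2)c2c(O)ccc3ccccc23)cc1` has nitro in place of methoxy on an aromatic carbon, para to a large group: nitro in place of methoxy on an aromatic carbon. Among the measured compounds shown here, the only measured step at this aryl group, a 1.3-fold higher number from compound 2 to compound 3 (0.12 log units; within the scatter), is small. Compound 1 also carries 4-nitrophenyl and gives 14700 nM, although its core differs. No change beyond the scatter is therefore expected in this assay. The estimated step is a 1.2-fold higher number from compound 3 to compound 4 (0.07 log units; within the scatter). For compound 4 the expected value is 11000 nM, with an estimated range of 5500 nM to 22000 nM.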

Compound 4, half-maximal inhibitory concentration: 6810 nM
Compound 4: the middle estimate sits 1.6-fold (0.21 log units) above what was measured; the measured number falls inside the stated range.
By their numbers in this assay, from the lowest: compounds 4, 2, 3 and 1 (each within the scatter of the next, the first and the last beyond it).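

In this assay, nitro in place of methoxy on this aromatic carbon stays within the scatter (a 1.4-fold lower number from compound 3 to compound 4 (0.14 log units; within the scatter)), as does 4-nitrophenyl in place of 3-methylphenyl (a 1.0-fold lower number from compound 2 to compound 4 (0.01 log units; within the scatter)), so these aryl groups are not separated by this read-out. Among the compounds shown here, the one step beyond the scatter lies elsewhere: 1,3-benzothiazol-2-yl in place of 5,6-dimethyl-1,3-benzothiazol-2-yl on the amine nitrogen, with 4-nitrophenyl kept, is a modest step (a 2.2-fold lower number from compound 1 to compound 4 (0.33 log units; beyond the scatter)). No available evidence bears on the cause of these steps.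

Open, as far as these compounds go, are whether an amine or a carboxylic acid in place of nitro would give a step beyond the scatter, and whether the benzothiazolyl step holds with methoxy in place of nitro.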